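The source may hold more compounds than are shown below. What is called first, only, known or untested is meant among the compounds shown, and "the series" means these compounds.

Series notes. Among the measured compounds shown here, compound 1 `COc1ccc(-n2c(SCc3ccccc3)nnc2-c2cc(OC)c(OC)c(OC)c2)cc1` carries a benzyl group on the sulfur of the shared core; in a functional assay on PC-3 cells (Homo sapiens) for inhibition, read by MTT assay, with a stated time of 48 h (on this read-out higher numbers stand for weaker inhibition and lower numbers for stronger inhibition), compound 1 gives 34100 nM, and the only other number measured so far, that of compound 2, sits within the scatter of it. Compound 2 `COc1ccc(-n2c(SCc3ccc(C)cc3)nnc2-c2cc(OC)c(OC)c(OC)c2)cc1` adds a methyl on an aromatic carbon; in this assay compound 2 gives 56500 nM. For the measured compounds named here, that step, a 1.7-fold higher number from compound 1 to compound 2 (0.22 log units; within the scatter), is the sole measured step in the set. Compound 3 `COc1ccc(-n2c(SCC(=O)c3ccc(OC)c(O)c3)nnc2-c2cc(OC)c(OC)c(OC)c2)cc1` is not yet measured; it replaces the phenyl of compound 1: (3-hydroxy-4-methoxyphenyl)carbonyl in place of phenyl on a saturated chain carbon bound to a sulfur. Going by the values given here, no measured step covers a change of this kind, and the one step recorded concerns a methyl on the aromatic ring and stays within the scatter, so no direction can be read from it. The expected step for compound 3 is therefore a 1.4-fold lower number from compound 1 to compound 3 (0.13 log units; within the scatter), carried with a wide range. Compound 3 is estimated at 25000 nM in this assay, between 6000 nM and 100000 nM.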

Compound 3, half-maximal inhibitory concentration: > 60000 nM
Compound 3 ended at the assay's limit; the forecaster's own chance of this, stated with the estimate: 15%; at least 2.4-fold (0.38 log units) between middle value and limit.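

Compound 3 gives no number in this assay, only a limit: the limit of > 60000 nM in this assay, at which 1 of the 3 values shown sits. The two steps to it, an at least 1.7-fold higher number from compound 1 to compound 3 (0.24 log units; that floor lies within the scatter) and an at least 1.0-fold higher number from compound 2 to compound 3 (0.02 log units; that floor lies within the scatter), are floors only, so neither fixes the true size of the change. Unlike the earlier methyl step on the aromatic ring, this change falls on the saturated chain carbon bound to a sulfur, and bringing in (3-hydroxy-4-methoxyphenyl)carbonyl there gives no reading of stronger inhibition than the phenyl of compound 1.

The compounds shown do not separate the carbonyl from the hydroxy and methoxy groups on the ring, as these enter together in compound 3. On these data alone, how an amine, a carboxylic acid or a longer chain would read at this place in this assay also remains open.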